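The source may report more compounds than this note shows. Statements on the series, on what has been measured and on what is new or still open speak of the compounds shown alone.

Compound 1 `Cc1ccc(/C=N/c2ccc(OCc3ccccc3)cc2)c(O)c1` gives 24400 nM in an assay on isolated protein for inhibition of Amine oxidase [flavin-containing] B (Homo sapiens), read by fluorescence and Amplex Red, with stated times of 15 min and 20 min; a higher number here means a weaker inhibitor, a lower number a stronger inhibitor. Compound 2 `Cc1ccc(O)c(/C=N/c2ccc(OCc3ccccc3)cc2)c1` gives 24600 nM in this assay; the step of a 1.0-fold higher number from compound 1 to compound 2 (0.00 log units; within the scatter) leaves the two within the scatter, so neither ranks above the other, and compound 2 stands at one of two closely agreeing numbers, its nearest neighbour being compound 1. Compound 3 `Oc1ccc(Cl)cc1/C=N/c1ccc(OCc2ccccc2)cc1` is the next member. Its difference from compound 2 is chloro in place of methyl on an aromatic carbon. For the measured compounds named here, no measured pair exchanges methyl for chloro, so nothing bears directly on this change; the only measured step, from compound 1 to compound 2, swaps 2-hydroxy-4-methylphenyl for 2-hydroxy-5-methylphenyl and shows no change beyond the scatter. With no indication either way, the step is expected to be a 1.1-fold lower number from compound 2 to compound 3 (0.05 log units; within the scatter), nothing beyond the scatter. Compound 3 is estimated at 22000 nM, within a range of 8000 nM to 60000 nM.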

Compound 3, half-maximal inhibitory concentration: 24800 nM
For compound 3 the middle estimate is 1.1-fold (0.05 log units) below the measured one; the measured number falls inside the stated range.
By their numbers in this assay, from the lowest: compounds 1, 2 and 3 (each within the scatter of the next).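

In this assay, chloro in place of methyl on an aromatic carbon, para to a hydroxy group and meta to a large group, gives a 1.0-fold higher number from compound 2 to compound 3 (0.00 log units; within the scatter). For the compounds shown here, this is the first exchange of one group for a different group here, whereas the earlier step only moved the methyl; the two groups, each of one heavy atom, cannot be told apart at this position. The step of a 1.0-fold higher number from compound 1 to compound 3 (0.01 log units; within the scatter) places the 5-chloro-2-hydroxyphenyl compound level with the 2-hydroxy-4-methylphenyl compound too, and no supporting data bear on why these numbers agree.

As far as these compounds go, whether a larger or charged group at this position, such as an amine, a carboxylic acid or a longer chain, would shift the number beyond the scatter remains open. From the compounds shown here alone, the contribution of the hydroxy group itself also remains open.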